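The compounds below may be only part of what the source reports. "The series", "measured", "known", "first", "only" and "open" are said of these compounds alone.

Compound 2 `CC(=O)Nc1cccc(-n2c(Nc3ccc(F)cc3)nc3cnc(Nc4ccc(N5CCN(C)CC5)cc4)nc32)c1` gives 10 nM in a functional assay on HCC827 cells (Homo sapiens) for antiproliferative activity, read by MTT assay, with a stated time of 72 h (a lower number here means a stronger inhibitor, a higher number a weaker inhibitor), the lowest of the two numbers seen so far; compound 1 `CN1CCN(c2ccc(Nc3ncc4nc(Nc5ccc(F)cc5)n([C@@H]5CCN(C(=O)CO)C5)c4n3)cc2)CC1` gives 350 nM in this assay. Compound 3 `CN1CCN(c2ccc(Nc3ncc4nc(Nc5ccc(F)cc5)n([C@@H]5CCN(C(=O)OC(C)(C)C)C5)c4n3)cc2)CC1` differs from compound 2 by 1-(tert-butoxycarbonyl)pyrrolidin-3-yl in place of 3-acetamidophenyl on an aromatic nitrogen. Going by the values given here, the one measured step that bears on this, a 35-fold lower number from compound 1 to compound 2 (1.54 log units; beyond the scatter), went the other way, exchanging a pyrrolidin-3-yl group carrying a carbonyl substituent for the aromatic group. Undoing that kind of change is expected to raise the number again, though the tert-butoxycarbonyl group itself is untested here. Compound 3 is therefore estimated at 200 nM, within a range of 60 nM to 700 nM, which means an expected step of a 20-fold higher number from compound 2 to compound 3 (1.30 log units; beyond the scatter).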

Compound 3, half-maximal inhibitory concentration: 27 nM
Compound 3: middle estimate off by 7.4-fold (0.87 log units), on the high side; the measured number lies below the stated range.
By their numbers in this assay, from the lowest: compound 2; then compound 3; then compound 1.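

The non-aromatic ring on this aromatic nitrogen is compatible with a low number: replacing 3-acetamidophenyl with 1-(tert-butoxycarbonyl)pyrrolidin-3-yl gives only a 2.7-fold higher number from compound 2 to compound 3 (0.43 log units; beyond the scatter). With the ring kept, the group on its carbonyl carbon has a far larger effect, as tert-butoxy in place of hydroxymethyl gives a 13-fold lower number from compound 1 to compound 3 (1.11 log units; beyond the scatter). No measurement shown here explains either step.

On these data alone, it remains open how a methyl, a dimethylamino or a cyclopropyl group on that carbonyl carbon would compare with tert-butoxy. As far as these compounds go, the effect of the ring's opposite stereocentre is also open.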